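A few compounds are considered here, and "the series" means these few. Any claim that something is new, unique, unknown or untested is made for them only; others in the source may bear on it.

Compound 1 `Cc1ccc(N2CCN(Cn3nc(-c4ccc5c(c4)OCCO5)oc3=S)CC2)c(C)c1` is reported in a functional assay on SW 1116 cells (Homo sapiens) for antiproliferative activity, read by MTT assay, with a stated time of 48 h (on this read-out lower numbers stand for stronger inhibition and higher numbers for weaker inhibition), only as a limit, > 50000 nM.
Compound 2 `COc1ccccc1N1CCN(Cn2nc(-c3ccc4c(c3)OCCO4)oc2=S)CC1` gives a measured number in this assay of 16900 nM.
Compound 3 `Fc1ccc(N2CCN(Cn3nc(-c4ccc5c(c4)OCCO5)oc3=S)CC2)cc1` is reported in this assay only as a limit, > 50000 nM.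

Compound 3 therefore stands at the top edge of the numbers shown, sharing the limit of > 50000 nM in this assay, at which 2 of the 3 values shown sit, with compound 1. Compound 4 `COc1cccc(N2CCN(Cn3nc(-c4ccc5c(c4)OCCO5)oc3=S)CC2)c1` differs from it in one place: 3-methoxyphenyl in place of 4-fluorophenyl on an amine nitrogen in a ring. Among the measured compounds shown here, two measured steps bear on this exchange of the group on the ring nitrogen. The step of an at least 2.9-fold higher number from compound 2 to compound 3 (0.47 log units; beyond the scatter) shows that replacing a methoxyphenyl by the 4-fluorophenyl lost measurable activity, and an at least 2.9-fold lower number from compound 1 to compound 2 (0.47 log units; beyond the scatter) points in the same direction for a methoxyphenyl, whereas a step that the two limits leave unreadable from compound 1 to compound 3. For the measured compounds named here, a methoxyphenyl thus once outperformed the fluorophenyl, but compound 4 carries a 3-methoxyphenyl rather than the 2-methoxyphenyl of compound 2, so no measured step matches it exactly. The expected step from the limit is an at least 1.6-fold lower number from compound 3 to compound 4 (0.22 log units; that floor lies within the scatter), a modest and uncertain gain. Compound 4 is estimated at about 30000 nM, between 10000 nM and 80000 nM, with a fair chance that only a limit is reported again.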

Compound 4, half-maximal inhibitory concentration: > 50000 nM
Compound 4 gave a limit, no number (the forecaster's own chance of this, stated with the estimate: 50%); middle value at least 1.6-fold (0.22 log units) from the limit.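

A methoxyphenyl on the ring nitrogen does not by itself give measurable activity: in this assay, putting the 3-methoxyphenyl in place of the 2-methoxyphenyl gives an at least 2.9-fold higher number from compound 2 to compound 4 (0.47 log units; beyond the scatter). Among the compounds shown, the result therefore depends on which methoxyphenyl is present, not merely on having one, and compound 2 remains the only one with a measured number: the limit of > 50000 nM in this assay, at which 3 of the 4 values shown sit. The steps from compound 1 and compound 3 to compound 4 cannot be read, since limits stand at both ends.

Compound 1, compound 3 and compound 4 therefore cannot be ranked against one another. Also open, going by these compounds, is how this position would respond to a 2-ethoxyphenyl, a 2-hydroxyphenyl or a benzyl group on the ring nitrogen.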